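The compounds below may be only part of what the source reports. "The series", "measured", "known", "first", "only" and "open" are said of these compounds alone.

Of the compounds shown here, three built on one shared core have been measured in a functional assay on SK-BR-3 cells (Homo sapiens) for inhibition, read by sulforhodamine B assay, with a stated time of 48 h; on this read-out higher numbers stand for weaker inhibition and lower numbers for stronger inhibition. Compound 1 `CO[C@@H]1CC=C2NN(c3ccc(Cl)cc3)C(=O)C[C@]2(C)O1` gives 28700 nM. Compound 2 `CO[C@@H]1CC=C2NN(c3cccnc3)C(=O)C[C@]2(C)O1` gives 15200 nM. Going by the values given here, compound 3 `CO[C@@H]1CC=C2NN(c3ccc(C)cc3)C(=O)C[C@]2(C)O1` gives 29700 nM, the highest of the three numbers, yet a 1.0-fold higher number from compound 1 to compound 3 (0.01 log units; within the scatter) and a 2.0-fold higher number from compound 2 to compound 3 (0.29 log units; within the scatter), so no compound stands apart from the others, and all three sit at weak inhibition.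

Compound 4 `CO[C@@H]1CC=C2NN(c3cncnc3)C(=O)C[C@]2(C)O1` differs from compound 3 in one place: pyrimidin-5-yl in place of 4-methylphenyl on an amide-type nitrogen in a ring. The measured step that bears most directly on this change is a 2.0-fold higher number from compound 2 to compound 3 (0.29 log units; within the scatter). That step likewise exchanges a six-membered aromatic ring of carbon only for a ring carrying ring nitrogen at the same place on the shared core. The step of a 1.9-fold lower number from compound 1 to compound 2 (0.28 log units; within the scatter) points the same way. Both steps fall within the scatter, so in this assay compound 4 is expected to show at most a modest shift toward a lower number, of a size that stays within the scatter rather than beyond it. The expected step is a 1.7-fold lower number from compound 3 to compound 4 (0.22 log units; within the scatter). Compound 4 is therefore estimated at 18000 nM, with a range from 7000 nM to 45000 nM.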

Compound 4, half-maximal inhibitory concentration: 3400 nM
Beside the measured number, compound 4's estimate is 5.3-fold (0.72 log units) above it; the whole stated range lies above it.
By their numbers in this assay, from the lowest: compound 4; then compounds 2, 1 and 3 (each within the scatter of the next).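

In this assay, going by these compounds alone, swapping 4-chlorophenyl, 4-methylphenyl and pyridin-3-yl on the amide-type nitrogen in a ring had left every step within the scatter, so this position looked insensitive to the group it carries, but pyrimidin-5-yl gives the first steps beyond it (from the carbon-only rings: an 8.7-fold lower number from compound 3 to compound 4 (0.94 log units; beyond the scatter) and an 8.4-fold lower number from compound 1 to compound 4 (0.93 log units; beyond the scatter)). Ring nitrogen alone does not separate the compounds, since pyridin-3-yl in compound 2 stays within the scatter of both carbon-only rings, while pyrimidin-5-yl stands apart from it as well (a 4.5-fold lower number from compound 2 to compound 4 (0.65 log units; beyond the scatter)), which makes this one specific ring, not any ring with nitrogen, the change that counts here. Nothing measured alongside these numbers explains the difference.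

As far as these compounds go, whether an amino group on the pyrimidin-5-yl ring, or a saturated ring such as morpholine in its place, would lower the number further remains open. From the compounds shown here alone, all four compounds also keep the methoxy group of the shared core, so it is equally open whether pyrimidin-5-yl keeps its advantage with a hydroxyl or an ethoxy group there.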